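This account rests on a few compounds, and the source may have more. Where it says the series, first, only, none or still open, it means among the compounds named here.

Of the compounds shown here, three that share one core have been tested in an ADME assay on Vero cells (Chlorocebus sabaeus) for cytotoxicity; a lower number here means that less compound is tolerated, a higher number that more compound is tolerated. Compound 1 `Fc1ccc(-c2nn3ccc(NC4CCCC4)cc3c2-c2ccnc(NC3CCCC3)n2)cc1` gives 18000 nM in this assay. Compound 2 `Fc1ccc(-c2nn3ccc(N4CCCC4)cc3c2-c2ccnc(NC3CCCC3)n2)cc1` reaches only a limit of the assay, > 40000 nM. Compound 3 `CC(C)Nc1ccn2nc(-c3ccc(F)cc3)c(-c3ccnc(NC4CCCC4)n3)c2c1` likewise reaches only a limit, > 40000 nM. Two of the three values thus sit at the limit of > 40000 nM in this assay, at which 2 of the 3 values shown sit, so compound 3 stands at a limit rather than at a number. The step of an at least 2.2-fold higher number from compound 1 to compound 2 (0.34 log units; beyond the scatter) and the step of an at least 2.2-fold higher number from compound 1 to compound 3 (0.34 log units; beyond the scatter) both point upward, while the step that the two limits leave unreadable from compound 2 to compound 3 cannot be read. Compound 4 `COc1ccn2nc(-c3ccc(F)cc3)c(-c3ccnc(NC4CCCC4)n3)c2c1` has not been measured yet; it differs from compound 3 in one place: methoxy in place of isopropylamino on an aromatic carbon. For the measured compounds named here, no measured step swaps an isopropylamino group for a methoxy group, so the only guide is the position of compound 3 at the limit. The expected step of a number no higher from compound 3 to compound 4 (the limit leaves the size open) is therefore none beyond the scatter, with a real chance that compound 4 again sits at the limit. The estimate for compound 4 is 40000 nM, ranging from 15000 nM to 80000 nM.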

Compound 4, half-maximal cytotoxic concentration: > 36000 nM
Compound 4: a limit, no number; the forecaster's own chance of this, stated with the estimate: 60%; the middle value is on the limit's open side.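

In this assay compound 4 also ends at a limit of the assay rather than at a number: the limit of > 36000 nM in this assay, at which 1 of the 4 values shown sits. For the compounds shown here, the methoxy group, which enters without the hydrogen-bond donor of isopropylamino, thus leaves cyclopentylamino in compound 1 as the only group at this position to give a number, though the comparison reads only as an at least 2.0-fold higher number from compound 1 to compound 4 (0.30 log units; that floor lies within the scatter), so it does not establish a real difference. The steps among compound 2, compound 3 and compound 4 cannot be read, since each has a limit at both ends: the limit of > 40000 nM in this assay, at which 2 of the 4 values shown sit.

From the compounds shown here alone, how far these three compounds really lie beyond their limits stays open, so any differences among them remain hidden. Also open, going by these compounds, is whether a carboxylic acid or a longer carbon chain at this position would give a readable number.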